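The source may hold more compounds than are shown below. What is called first, only, known or untested is meant among the compounds shown, and "the series" means these compounds.

Working notes on the series.

Three members have been run in an assay on cells for agonist activity at D(4) dopamine receptor (Homo sapiens), read by luminescence and beta-arrestin recruitment, with a stated time of 90 min; a lower number here means that less compound is needed, a higher number that more compound is needed for the effect. Going by the values given here, compound 2 `O=C(CN1CCN(c2ccccn2)CC1)Nc1cccnc1` gives 2660 nM and is the only member with a number. Compound 1 `Cc1cccc(NC(=O)CN2CCC(c3ccc(Cl)cc3)CC2)c1` is reported as "not active" (no number reported). Compound 3 `Cc1cccc(NC(=O)CCN2CCN(c3ccccn3)CC2)c1` is likewise reported as "not active" (no number reported). Compound 2 therefore stands alone on the numbers shown. Among the compounds with values here, no step between measured members can be stated; the other two have no number against which compound 2 could be set.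

The next member, compound 4 `Cc1cccc(NC(=O)CN2CCN(c3ccccn3)CC2)c1`, is not yet measured. It differs from compound 2 by 3-methylphenyl in place of pyridin-3-yl on an amide-type nitrogen. Within the data shown here, both compound 1 and compound 3 carry the 3-methylphenyl group on an amide-type nitrogen and neither returned a number in this assay, whereas compound 2, the one member with a number, carries pyridin-3-yl at that place. On this basis the step expected in this assay from compound 2 to compound 4 is toward a higher number, beyond the scatter, with a real chance that only a limit is reported.

The estimate for compound 4 in this assay is 7000 nM, with a range of 1500 nM to 30000 nM. This means an expected step of a 2.6-fold higher number from compound 2 to compound 4 (0.42 log units; beyond the scatter).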

Compound 4, half-maximal effective concentration: 394 nM
The estimate for compound 4 lay 18-fold (1.25 log units) above the measured number; the whole stated range lies above it.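

In this assay, 3-methylphenyl in place of pyridin-3-yl on the amide-type nitrogen gives a 6.8-fold lower number from compound 2 to compound 4 (0.83 log units; beyond the scatter), so this position tolerates the carbocyclic group and the 3-methylphenyl group does not by itself go with the absence of a number, as compound 1 and compound 3 alone had suggested. Compound 3 still gives "not active" (no number reported) and compound 1 gives "not active" (no number reported), so with the same group on that nitrogen the outcome depends on what else differs from compound 4, though steps to these two compounds cannot be read. Nothing on hand accounts for the size of the step, and its cause stays unassigned.

The compounds shown leave open whether the step belongs to the added methyl or to ring carbon replacing ring nitrogen, a question that an unsubstituted phenyl group on the same nitrogen would separate. Also open, on these data alone, is how far the gain extends to other groups at this place, such as a chlorophenyl or a methoxyphenyl group.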